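Chloro on a biaryl analogue with no measured potency

A few compounds are considered here, and "the series" means these few. Any claim that something is new, unique, unknown or untested is made for them only; others in the source may bear on it.

Values in a functional assay on SEM cells (Homo sapiens) for cytotoxicity, with a stated time of 72 h; on this read-out lower numbers stand for an effect already at smaller amounts and higher numbers for an effect only at larger amounts of compound:
compound 1 `C=C[C@@](C)(/C=C/c1ccc(Nc2ccccc2)cc1)CCC=C(C)C`: > 36600 nM (a limit)
compound 2 `C=C[C@@](C)(/C=C/c1ccc(Nc2ccc(Cl)c(Cl)c2)cc1)CCC=C(C)C`: > 36600 nM (a limit)
compound 3 `C=C[C@@](C)(/C=C/c1ccc(-c2ccccc2)cc1)CCC=C(C)C`: > 36600 nM (a limit)

Compound 3 stands at > 36600 nM, which is a limit and not a number. It has no place of its own in the series, since the record so far is the limit of > 36600 nM in this assay, at which 3 of the 3 values shown sit.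

Compound 4 `C=C[C@@](C)(/C=C/c1ccc(-c2ccc(Cl)cc2)cc1)CCC=C(C)C` carries chloro in place of hydrogen on an aromatic carbon, para to a large group: chloro in place of hydrogen on an aromatic carbon.

Among the compounds with values here, the nearest precedent for adding chlorine is a step that the two limits leave unreadable from compound 1 to compound 2, which puts 3,4-dichlorophenyl in place of phenyl on a nitrogen on an aromatic ring. The other two steps, a step that the two limits leave unreadable from compound 1 to compound 3 and a step that the two limits leave unreadable from compound 2 to compound 3, give no size either. Within the data shown here, no measured step therefore supports a shift in either direction, and no step beyond the scatter is expected in this assay. The expected change is a step that the limit leaves unreadable from compound 3 to compound 4. A report of only a limit is again the likeliest outcome for the new compound. For compound 4 the estimated value is 40000 nM, with an expected range from 15000 nM to 100000 nM.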

Compound 4, half-maximal effective concentration: > 36600 nM
Compound 4: no number, only a limit (the forecaster's own chance of this, stated with the estimate: 85%); the middle value lies beyond the limit too.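

In this assay compound 4 gives > 36600 nM, which is a limit and not a number. No step to compound 4 from compound 1, compound 2 or compound 3 can be read: the limit of > 36600 nM in this assay, at which 4 of the 4 values shown sit.

The compounds shown leave open whether any change on the shared core would give a measurable value in this assay, and what size of step chloro would then produce.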